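Swapping the Ring Substituent on the Amine Nitrogen

The source may report more compounds than this note shows. Statements on the series, on what has been measured and on what is new or still open speak of the compounds shown alone.

Three compounds share one core and differ only in the group carried on an amine nitrogen. In a functional assay on HeLa cells (Homo sapiens) for cytotoxicity, read by MTT assay, with a stated time of 48 h (on this read-out higher numbers stand for weaker inhibition and lower numbers for stronger inhibition), compound 1 `Cc1ccc(S(=O)(=O)/N=C(/CCNC2=CC(=O)c3ccccc3C2=O)Nc2ccc(F)cc2)cc1` gives 5890 nM, compound 2 `COc1ccc(N/C(CCNC2=CC(=O)c3ccccc3C2=O)=N\S(=O)(=O)c2ccc(C)cc2)cc1OC` gives 14500 nM, and compound 3 `Cc1ccc(S(=O)(=O)/N=C(/CCNC2=CC(=O)c3ccccc3C2=O)NC(C)C)cc1` gives 30200 nM. Among these three numbers compound 2 stands second highest: its nearest neighbour is compound 3, reached by a 2.1-fold higher number from compound 2 to compound 3 (0.32 log units; beyond the scatter), and its furthest is compound 1, separated by a 2.5-fold higher number from compound 1 to compound 2 (0.39 log units; beyond the scatter). The remaining step, a 5.1-fold higher number from compound 1 to compound 3 (0.71 log units; beyond the scatter), spans the whole set. Compound 4 `Cc1ccc(S(=O)(=O)/N=C(/CCNC2=CC(=O)c3ccccc3C2=O)NCc2ccccc2)cc1` introduces (benzyl in place of 3,4-dimethoxyphenyl on an amine nitrogen). Going by the values given here, the two steps that start or end at compound 2 both exchange one nitrogen substituent for another and both were modest, so a change of similar size is plausible here, but the direction is unclear, since the benzyl group has no counterpart among the measured compounds. The expected value for compound 4 in this assay is 15000 nM, estimated to fall between 6000 nM and 40000 nM. This estimate amounts to an expected step of a 1.0-fold higher number from compound 2 to compound 4 (0.01 log units; within the scatter), not clearly beyond the scatter.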

Compound 4, half-maximal inhibitory concentration: 3980 nM
Compound 4: the middle estimate sits 3.8-fold (0.58 log units) above what was measured; the measured number lies below the stated range.
By their numbers in this assay, from the lowest: compounds 4 and 1 (each within the scatter of the next); then compound 2; then compound 3.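

Going by these compounds alone, a benzyl group on this amine nitrogen gives one of the two lowest numbers so far: in this assay the exchange brings a 3.6-fold lower number from compound 2 to compound 4 (0.56 log units; beyond the scatter) and also a 7.6-fold lower number from compound 3 to compound 4 (0.88 log units; beyond the scatter). Against the 4-fluorophenyl group, benzyl cannot be told apart, as a 1.5-fold lower number from compound 1 to compound 4 (0.17 log units; within the scatter) and this step does not separate the two groups. Carrying a six-membered aromatic ring does not by itself place a compound at the low end, as compound 2 also has one yet its number stays clearly higher than those of compound 1 and compound 4.

No measurement shown here explains why these groups differ. Going by these compounds, it remains open whether a 4-fluorobenzyl group, which would combine features of compound 1 and compound 4, or a longer chain such as 2-phenylethyl, would lower the number further.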